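Notes on the step from compound 1 to compound 4

The compounds below may be only part of what the source reports. "The series", "measured", "known", "first", "only" and "open" are said of these compounds alone.

compound 1 `O=C(CC(c1ccc(F)cc1)C(C(=O)Nc1ccccn1)C(=O)Nc1ccccn1)c1ccccc1` gives 20800 nM
compound 2 `O=C(CC(c1ccc(F)cc1)C(C(=O)Nc1ccccn1)C(=O)Nc1ccccn1)c1ccc(F)cc1` gives 25500 nM
compound 3 `O=C(CC(c1ccc(Cl)cc1)C(C(=O)Nc1ccccn1)C(=O)Nc1ccccn1)c1ccc(F)cc1` gives 4100 nM

All three numbers come from a functional assay on HeLa cells (Homo sapiens) for inhibition, read by MTT assay, with a stated time of 48 h (on this read-out lower numbers stand for stronger inhibition and higher numbers for weaker inhibition), as the single read-out. Compound 1 at 20800 nM sits with compound 2 at the high end of these numbers, the two lying within the scatter of each other, and compound 3, clearly apart from both in the direction of stronger inhibition, gives 4100 nM on the same scale.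

The next structure is compound 4 `O=C(CC(c1ccc(Cl)cc1Cl)C(C(=O)Nc1ccccn1)C(=O)Nc1ccccn1)c1ccccc1` and it differs from compound 1 by 2,4-dichlorophenyl in place of 4-fluorophenyl on a saturated chain carbon bound to two saturated chain carbons in the shared core. In words, this is 2,4-dichlorophenyl in place of 4-fluorophenyl on a saturated chain carbon bound to two saturated chain carbons.

The closest measured precedent is the swap of chloro for fluoro on that same group, with a 6.2-fold lower number from compound 2 to compound 3 (0.79 log units; beyond the scatter) as its modest size. The other measured step, a 1.2-fold higher number from compound 1 to compound 2 (0.09 log units; within the scatter) as its size, concerns a different aromatic carbon and calls for no correction. Among the compounds with values here, no measured compound carries a second chlorine, so its contribution is unknown and the margin must stay wide.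

A move to a lower number, of about the size of the chloro swap, is therefore expected. The estimated step is a 4.6-fold lower number from compound 1 to compound 4 (0.66 log units; beyond the scatter) and it remains an expectation until measured. For compound 4 the expected value is 4500 nM with an estimated range from 1500 nM to 13000 nM in this assay here.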

Compound 4, half-maximal inhibitory concentration: 13500 nM
For compound 4 the middle estimate is 3.0-fold (0.48 log units) below the measured one; measured number outside the range, above it.
By their numbers in this assay, from the lowest: compound 3; then compounds 4, 1 and 2 (each within the scatter of the next).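

In this assay 2,4-dichlorophenyl in place of 4-fluorophenyl on a saturated chain carbon bound to two saturated chain carbons gives a step within the scatter (a 1.5-fold lower number from compound 1 to compound 4 (0.19 log units; within the scatter)), so this position accepts the larger dichlorinated group on the core of compound 1 with no measurable change in the read-out. Within the data shown here, the only earlier change at this group (a 6.2-fold lower number from compound 2 to compound 3 (0.79 log units; beyond the scatter)) lay beyond the scatter, which now shows that chlorine on this ring does not bring a step of that size in every setting. The two steps differ both in the entering group and in the other aromatic ring of the compounds, and nothing measured here bears on why they part ways.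

The compounds shown offer no pair differing in one place that separates the contribution of the added chlorine from that of the fluoro on the other aromatic ring. As far as these compounds go, how this position answers to groups other than halogens, such as a methoxy group or an amine on the ring, also stays open.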